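The compounds below may be only part of what the source reports. "The series", "measured", "known", "first", "only" and "open" are said of these compounds alone.

Working notes on the series, read in a functional assay on SK-N-MC cells (Homo sapiens) for cytotoxicity, read by MTT assay; on this read-out higher numbers stand for weaker inhibition and lower numbers for stronger inhibition. Compound 1 `COc1ccc(/C=C2\CCC/C(=C\c3cccc([N+](=O)[O-])c3)C2=O)cc1` gives 10.4 ug/mL. Compound 2 `COc1cc(/C=C2\CCC/C(=C\c3ccc([N+](=O)[O-])cc3)C2=O)ccc1O` gives 48 ug/mL. Compound 3 `COc1cc(/C=C2\CCC/C(=C\c3ccc([N+](=O)[O-])cc3)C2=O)cc(Br)c1O` gives 16.8 ug/mL. Among the measured compounds shown here, the one step between measured compounds that differ in a single place is a 2.9-fold lower number from compound 2 to compound 3 (0.46 log units; beyond the scatter). On the three numbers, compound 3 stands apart from compound 2 beyond the scatter, while its gap to compound 1 lies within the scatter, so no order between compound 3 and compound 1 is claimed.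

Compound 4 `CCOc1c(Br)cc(/C=C2\CCC/C(=C\c3ccc([N+](=O)[O-])cc3)C2=O)cc1OC` is not yet measured. Its difference from compound 3 is ethyl in place of hydrogen on an oxygen on an aromatic ring; cut one bond further out, the change reads hydroxy to ethoxy. For the measured compounds named here, no measured step touches this oxygen: the only step available, a 2.9-fold lower number from compound 2 to compound 3 (0.46 log units; beyond the scatter), concerns a bromo entering on an aromatic carbon and has no direct bearing on an ethyl entering on an oxygen. Going by the values given here, compound 1 and compound 2 differ in several places at once, and their two values show only that the numbers differ beyond the scatter. With no anchor for this change, the step expected for compound 4 in this assay is a 1.1-fold higher number from compound 3 to compound 4 (0.03 log units; within the scatter), none beyond the scatter in either direction. Compound 4 is therefore estimated at 18 ug/mL, with a range from 7 ug/mL to 45 ug/mL.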

Compound 4, half-maximal inhibitory concentration: 3.91 ug/mL
The estimate for compound 4 lay 4.6-fold (0.66 log units) above the measured number; the whole stated range lies above it.
By their numbers in this assay, from the lowest: compound 4; then compounds 1 and 3 (each within the scatter of the next); then compound 2.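

In this assay, among the compounds shown here, the oxygen on the aromatic ring proves to be a position where the number can move: ethyl in place of hydrogen, read one bond further out as hydroxy to ethoxy, gives a 4.3-fold lower number from compound 3 to compound 4 (0.63 log units; beyond the scatter) on the series, and this is the first measured step at this oxygen. The earlier step, a 2.9-fold lower number from compound 2 to compound 3 (0.46 log units; beyond the scatter) for a bromo in place of hydrogen on an aromatic carbon, concerned another place, so two single-place changes on this series now both lead to lower numbers, and neither of the two steps shown goes against that direction, although two steps make only a small sample. The data shown hold no measurement that bears on what lies behind the step at this oxygen.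

The compounds shown leave open whether the step belongs to ethyl in particular or would also appear with methyl, a longer chain such as butyl, or a chain ending in an amine or a carboxylic acid on the same oxygen. They also leave open whether hydroxy to ethoxy gives a similar step when the bromo is absent, as in compound 2.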